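Swapping the Aryl Group on the Ring Nitrogen

The source may hold more compounds than are shown below. What is called first, only, known or untested is meant among the compounds shown, and "the series" means these compounds.

Among three compounds built on one shared core, compound 1 `COc1cc2c(Oc3ccc(NC(=O)c4nn(-c5cccc(F)c5)c(=O)c5ccccc45)cc3F)ccnc2cc1OCCCN1CCCC1` gives 880 nM in a functional assay on MDA-MB-231 cells (Homo sapiens) for cytotoxicity, read by MTT assay, with a stated time of 72 h; on this read-out lower numbers stand for stronger inhibition and higher numbers for weaker inhibition. That is the lowest of the three numbers, though the others sit within the scatter of it: compound 2 `COc1cc2c(Oc3ccc(NC(=O)c4nn(-c5ccccc5F)c(=O)c5ccccc45)cc3F)ccnc2cc1OCCCN1CCCC1` gives 950 nM in this assay, and compound 3 `COc1cc2c(Oc3ccc(NC(=O)c4nn(-c5ccc(Br)cc5)c(=O)c5ccccc45)cc3F)ccnc2cc1OCCCN1CCCC1` gives 1160 nM in this assay. The steps among them are all small: a 1.1-fold higher number from compound 1 to compound 2 (0.03 log units; within the scatter), a 1.3-fold higher number from compound 1 to compound 3 (0.12 log units; within the scatter) and a 1.2-fold higher number from compound 2 to compound 3 (0.09 log units; within the scatter).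

Compound 4 `COc1cc2c(Oc3ccc(NC(=O)c4nn(-c5ccc([N+](=O)[O-])cc5)c(=O)c5ccccc45)cc3F)ccnc2cc1OCCCN1CCCC1` differs from compound 1 in one place: 4-nitrophenyl in place of 3-fluorophenyl on an aromatic nitrogen. All three measured steps bear on this change, since each of them also exchanges the aryl group on that same aromatic nitrogen, and none of them moved the number beyond the scatter. From the compounds shown here alone, a 4-nitrophenyl group has not been tried, so the acceptors it brings are untested here; but with three such swaps all flat, a step of little size is expected in this assay, with no direction favoured. The step from compound 1 is therefore expected to be a 1.1-fold higher number from compound 1 to compound 4 (0.06 log units; within the scatter). For compound 4 the expected value in this assay is 1000 nM, with a range from 500 nM to 2000 nM.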

Compound 4, half-maximal inhibitory concentration: 2980 nM
Compound 4: middle estimate off by 3.0-fold (0.47 log units), on the low side, and the stated range ends below it.
By their numbers in this assay, from the lowest: compounds 1, 2 and 3 (each within the scatter of the next); then compound 4.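

The aryl group on this ring nitrogen proves less freely exchangeable in this assay than the three halogen-bearing compounds suggested: the 4-nitrophenyl group gives a 3.4-fold higher number from compound 1 to compound 4 (0.53 log units; beyond the scatter) and also a 3.1-fold higher number from compound 2 to compound 4 (0.50 log units; beyond the scatter) as a step beyond the scatter, so compound 4 is the weakest of the four by all its printed steps. The closest comparison is the exchange of one substituent on the same aryl ring, nitro in place of bromo, which gives a 2.6-fold higher number from compound 3 to compound 4 (0.41 log units; beyond the scatter) and shows that this single change is enough to separate compound 4 from a group of compounds that otherwise stay within the scatter of one another. Nothing available explains why the number rises with this change.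

With a single nitro compound, the shift cannot yet be assigned to the nitro group in particular rather than to leaving the halogens behind. From the compounds shown here alone, an aryl ring carrying a nitrile, an amine or a carboxylic acid in place of the nitro would show whether the rise is particular to nitro, and whether it also appears outside this one cell line remains open.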